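Chain Length and Cytotoxicity in a Cytidine Ester Series

The source may report more compounds than this note shows. Statements on the series, on what has been measured and on what is new or still open speak of the compounds shown alone.

Three esters of the same cytidine core have been measured in a functional assay on HeLa cells (Homo sapiens) for cytotoxicity, read by cell counting, with a stated time of 48 h; a lower number here means that less compound is needed, a higher number that more compound is needed for the effect. Compound 1 `CCCCCCCCCCCCCCCCCCCCCC(=O)O[C@H]1[C@H](O)[C@H](n2ccc(N)nc2=O)O[C@@H]1CO` gives 1.1 ug/mL, compound 2 `CCCCCCCCCCCCCCCC(=O)O[C@H]1[C@H](O)[C@H](n2ccc(N)nc2=O)O[C@@H]1CO` gives 0.24 ug/mL, and compound 3 `CCCCCCCCCC(=O)O[C@H]1[C@H](O)[C@H](n2ccc(N)nc2=O)O[C@@H]1CO` gives 0.09 ug/mL. Compound 3 therefore stands at the lowest number of the three, with compound 2 nearest and compound 1 furthest away. Each shortening of the acyl chain has lowered the number: a 4.6-fold lower number from compound 1 to compound 2 (0.66 log units; beyond the scatter), a 2.7-fold lower number from compound 2 to compound 3 (0.43 log units; beyond the scatter), and across both at once a 12-fold lower number from compound 1 to compound 3 (1.09 log units; beyond the scatter).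

Compound 4 `CCCCCCCCCCCCCCCCCC(=O)O[C@H]1[C@H](O)[C@H](n2ccc(N)nc2=O)O[C@@H]1CO` goes back the other way. It differs from compound 3 by octyl in place of hydrogen on a saturated chain carbon, nine bonds along the chain from a carbonyl carbon, a change that lengthens the chain by more than the hexyl removed between compound 2 and compound 3 but by less than the dodecyl removed between compound 1 and compound 3. The two steps that bear on it are thus the reverse of those two: adding hexyl at the same place raised the number in this assay modestly, and adding dodecyl raised it by a large amount. An octyl addition is expected to fall between them, giving a higher number beyond the scatter, a 4.4-fold higher number from compound 3 to compound 4 (0.65 log units; beyond the scatter). Compound 4 is accordingly estimated at 0.4 ug/mL, within a range from 0.2 ug/mL to 0.9 ug/mL.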

Compound 4, concentration for half-maximal effect: 0.13 ug/mL
Compound 4: middle estimate off by 3.1-fold (0.49 log units), on the high side, outside the stated range (below it).
By their numbers in this assay, from the lowest: compounds 3, 4 and 2 (each within the scatter of the next, the first and the last beyond it); then compound 1.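

At this place on the chain, nine bonds along from a carbonyl carbon, octyl in place of hydrogen leaves compound 3 and compound 4 within the scatter of each other in this assay (a 1.4-fold higher number from compound 3 to compound 4 (0.16 log units; within the scatter)), although the smaller hexyl change had separated compound 2 and compound 3 beyond it (a 2.7-fold lower number from compound 2 to compound 3 (0.43 log units; beyond the scatter)). The added length therefore does not raise the number in step with chain size: ethyl in place of hydrogen, further out on the chain, also stays within the scatter (a 1.8-fold lower number from compound 2 to compound 4 (0.27 log units; within the scatter)), so compound 4 does not follow the rise that the first three compounds suggested. Only compound 1 remains clearly apart, with hydrogen in place of butyl on the chain of compound 1 giving a clear drop (an 8.5-fold lower number from compound 1 to compound 4 (0.93 log units; beyond the scatter)), so among these esters the marked loss appears only at the longest chain.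

Nothing shown explains why the number stays flat over this stretch of chain. From the compounds shown here alone, it also remains open how a chain shorter than that of compound 3, or one ending in an amine or a carboxylic acid, would read at this position.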